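The compounds below may be only part of what the source reports. "The series", "measured", "known", "first", "only" and "open" are said of these compounds alone.

Working notes on the series. Compound 1 `O=C(O)c1ccc(-c2ccccc2)cc1O` has the same core as compound 2 `CCCCOC(=O)Oc1ccc(-c2ccc(F)cc2)cc1C(=O)O` and compound 3 `CCCCOC(=O)Oc1ccc(-c2ccc(F)cc2F)cc1C(=O)O`; how the core of compound 1 differs from that of compound 2 is not broken down here. In a functional assay on the whole organism with Rattus norvegicus as the target (a lower number here means that less compound is needed, a higher number that more compound is needed for the effect), compound 1 gives 150 mg/kg, compound 2 gives 25 mg/kg, and compound 3 gives 12 mg/kg; compound 1 stands highest of the three. The change from compound 2 to compound 3 is fluoro in place of hydrogen on an aromatic carbon and gave a 2.1-fold lower number from compound 2 to compound 3 (0.32 log units; beyond the scatter). Compound 4 `O=C(O)c1ccc(-c2ccc(F)cc2)cc1O` is not yet measured. Its change from compound 1 is fluoro in place of hydrogen on an aromatic carbon, the same kind of change, but here the fluoro enters para to a large group, while in compound 3 it enters ortho to a large group and meta to a fluoro group. Among the compounds with values here, the expected step, resting only on the single measured step of a 2.1-fold lower number from compound 2 to compound 3 (0.32 log units; beyond the scatter), is a 2.0-fold lower number from compound 1 to compound 4 (0.30 log units; within the scatter). Compound 4 is thus estimated at 75 mg/kg, with 40 mg/kg and 150 mg/kg as the ends of the range.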

Compound 4, dose for half-maximal effect: 400 mg/kg
The estimate for compound 4 lay 5.3-fold (0.73 log units) below the measured number; the whole stated range lies below it.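

Fluoro in place of hydrogen gave a 2.7-fold higher number from compound 1 to compound 4 (0.43 log units; beyond the scatter), opposite in direction to the earlier step, so in this assay the effect of this change does not carry over from one core to the other in size or in direction: the same change on two cores in this assay, a 2.1-fold lower number (0.32 log units; beyond the scatter) from compound 2 to compound 3 and a 2.7-fold higher number (0.43 log units; beyond the scatter) from compound 1 to compound 4, 5.6-fold (0.74 log units) apart, beyond the scatter of two such steps

This does not show what sets the difference, as the two steps differ in the core and also in where the fluoro enters, para to a large group in compound 4 and at another place on the ring in compound 3. With a single step on each core, it also gives no general rule for the series.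

Still open, as far as these compounds go, is whether the core or the place of the fluoro decides the direction of the step. Also open, from the compounds shown here alone, is whether chloro or methyl in place of the fluoro of compound 4 would move the number the same way.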